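A methoxy in place of thiophene on the shared core

The source may hold more compounds than are shown below. What is called first, only, known or untested is meant among the compounds shown, and "the series" means these compounds.

Compound 3 `c1csc(Sc2c[nH]c3ncnc(-c4cccs4)c23)c1` stands at the limit of the assay: in a functional assay on HeLa S3 cells (Homo sapiens) for cytotoxicity, read by XTT assay, with a stated time of 6 days (a higher number here means a weaker inhibitor, a lower number a stronger inhibitor), compound 3 gives > 25000 nM, a limit rather than a number. Compound 1 `CN(C)c1ncnc2[nH]cc(Sc3cccs3)c12` likewise sits at a limit, giving > 25000 nM in this assay. Compound 2 `CNc1ncnc2[nH]cc(Sc3cccs3)c12` gives 17600 nM in this assay. The step of an at least 1.4-fold lower number from compound 1 to compound 2 (0.15 log units; that floor lies within the scatter) and the step of an at least 1.4-fold higher number from compound 2 to compound 3 (0.15 log units; that floor lies within the scatter) are both only floors, and the step that the two limits leave unreadable from compound 1 to compound 3 cannot be read, as the limit of > 25000 nM in this assay, at which 2 of the 3 values shown sit, records. Compound 4 `COc1ncnc2[nH]cc(Sc3cccs3)c12` differs from compound 3 by methoxy in place of thiophen-2-yl on an aromatic carbon. Going by the values given here, no measured step exchanges thiophen-2-yl for methoxy, so the step of an at least 1.2-fold lower number from compound 3 to compound 4 (0.09 log units; that floor lies within the scatter) is expected to stay within the scatter. Compound 4 is thus expected at 20000 nM, with a range from 7000 nM to 60000 nM.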

Compound 4, half-maximal inhibitory concentration: 23900 nM
For compound 4 the middle estimate is 1.2-fold (0.08 log units) below the measured one; the range from low to high includes it.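

Going by these compounds alone, at this aromatic carbon, methoxy gives the first exchange with numbers at both ends in this assay, a 1.4-fold higher number from compound 2 to compound 4 (0.13 log units; within the scatter), so compound 2 and compound 4 cannot be told apart. The values of compound 1 and compound 3 are limits, which leaves only floors: an at least 1.0-fold lower number from compound 3 to compound 4 (0.01 log units; that floor lies within the scatter), and an at least 1.0-fold lower number from compound 1 to compound 4 (0.01 log units; that floor lies within the scatter). Neither floor separates methoxy from thiophen-2-yl or dimethylamino.

On these data alone, whether an unsubstituted amine, a carboxylic acid or a longer alkoxy chain on this carbon would move the number beyond the scatter stays open.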